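The source may report more compounds than this note shows. Statements on the series, on what has been measured and on what is new or still open speak of the compounds shown alone.

Measured so far:
compound 1, `COc1cccc(/C=C/C(=O)c2ccc(OC)c3c2OC(C)(C)C=C3)c1` — > 10000 nM
compound 2, `COc1ccc(C(=O)/C=C/c2ccsc2)c2c1C=CC(C)(C)O2` — > 10000 nM
compound 3, `COc1ccc(C(=O)/C=C/c2cccs2)c2c1C=CC(C)(C)O2` — > 10000 nM

Compound 1 stands only at a limit in a functional assay on HCT-116 cells (Homo sapiens) for antiproliferative activity, read by MTT assay, with a stated time of 24 h; on this read-out lower numbers stand for stronger inhibition and higher numbers for weaker inhibition: the value > 10000 nM is a limit of the assay, not a number. The same holds for compound 2, whose > 10000 nM is a limit. Compound 3 likewise gives > 10000 nM, again a limit. Because of the limit of > 10000 nM in this assay, at which 3 of the 3 values shown sit, none of the steps among them can be read: a step that the two limits leave unreadable from compound 1 to compound 2, a step that the two limits leave unreadable from compound 1 to compound 3 and a step that the two limits leave unreadable from compound 2 to compound 3 all remain of unreadable size, and the thiophene exchanges say nothing about the direction of further changes.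

The next compound, compound 4, `COc1ccc(C(=O)/C=C/c2cccc(O)c2)c2c1C=CC(C)(C)O2`, keeps the aryl of compound 1 and changes only (hydrogen in place of methyl on an oxygen on an aromatic ring). Among the measured compounds shown here, no measured step bears directly on this change; all three measured values sit at the limit, so the series gives no scale for it. Compound 4 is therefore expected to sit near the same limit, estimated at 15000 nM with a range from 4000 nM to 50000 nM. This corresponds to an expected step that the limit leaves unreadable from compound 1 to compound 4, with a high chance that only a limit is reported.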

Compound 4, half-maximal inhibitory concentration: > 10000 nM
Compound 4 was reported as a limit; the forecaster's own chance of this, stated with the estimate: 70%; the middle value lies beyond the limit too.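

No step from compound 1, compound 2 or compound 3 to compound 4 can be read, because each of the four compounds stands at a limit: the limit of > 10000 nM in this assay, at which 4 of the 4 values shown sit.

As far as these compounds go, the order of 3-methoxyphenyl, 3-hydroxyphenyl and the two thiophenes on the shared core stays open, as does what would bring a value inside the limit.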